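The source may report more compounds than this note shows. Statements on the series, on what has been measured and on what is new or still open speak of the compounds shown alone.

In an in vitro ADME assay on microsomes from liver (Homo sapiens) for metabolic stability, tested at 5 uM (a higher number here means that the compound lasts longer, a lower number that the compound disappears faster), compound 1 `CC(C)CCn1nc(-c2cccs2)c(O)c(C2=NS(=O)(=O)c3cc(CS(C)(=O)=O)ccc3N2)c1=O` gives 0.467 h and compound 2 `CC(C)CCn1nc(-c2ccccc2)c(O)c(C2=NS(=O)(=O)c3cc(NS(C)(=O)=O)ccc3N2)c1=O` gives 0.633 h. Among the measured compounds shown here, these two values lie within the scatter of each other, so compound 2 stands level with compound 1 on the only numbers available.

Compound 3 `CC(C)CCn1nc(C2=CCCC2)c(O)c(C2=NS(=O)(=O)c3cc(NS(C)(=O)=O)ccc3N2)c1=O` differs from compound 2 by one change: cyclopent-1-en-1-yl in place of phenyl on an aromatic carbon. It carries cyclopent-1-en-1-yl in place of phenyl on an aromatic carbon, ortho to a hydroxy group and meta to an isopentyl group.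

For the measured compounds named here, no measured pair shows this change, so the data offer no direct guide to its size. A small move toward faster disappearance is expected in this assay, probably not clearly beyond the scatter. The expected change is a 1.4-fold lower number from compound 2 to compound 3 (0.15 log units; within the scatter). For compound 3 the estimated half-life is 0.45 h, with an expected range of 0.2 h to 0.9 h.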

Compound 3, half-life: 0.933 h
For compound 3 the middle estimate is 2.1-fold (0.32 log units) below the measured one; measured number above the stated range.
By their numbers in this assay, from the lowest: compounds 1, 2 and 3 (each within the scatter of the next).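

In this assay, among the compounds shown here, cyclopent-1-en-1-yl in place of phenyl on the aromatic carbon ortho to a hydroxy group gives a 1.5-fold higher number from compound 2 to compound 3 (0.17 log units; within the scatter) as the first single-place step. At this position, therefore, a five-membered non-aromatic ring of carbon only and a six-membered aromatic ring of carbon only cannot be told apart by half-life in these data, so the aromatic ring is not shown to be needed to hold the number at this level. Nothing measured here bears on why the two groups read alike.

Still open, as far as these compounds go, is whether a saturated cyclopentyl ring, an open chain such as isobutyl, or a phenyl ring carrying an amine at this position would give a step beyond the scatter. From the compounds shown here alone, the isopentyl group is the same in all three compounds, so a shorter chain or a chain ending in a carboxylic acid remains untested in these data.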